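From 4-nitrophenyl to 2-fluorophenyl: an expected step

The source may hold more compounds than are shown below. What is called first, only, known or untested is meant among the compounds shown, and "the series" means these compounds.

Measured so far in a functional assay on SW-620 cells (Homo sapiens) for cytotoxicity, read by sulforhodamine B assay, with a stated time of 48 h; a higher number here means a weaker inhibitor, a lower number a stronger inhibitor:

compound 1 `C[C@H]1CC[C@@H]2[C@@H](OC(=O)[C@]23CC(c2c(Cl)cccc2Cl)=NO3)[C@]2(C)C(=O)C=C[C@@]12O` gives 43000 nM
compound 2 `COc1ccc(C2=NO[C@]3(C2)C(=O)O[C@@H]2[C@H]3CC[C@H](C)[C@]3(O)C=CC(=O)[C@@]23C)cc1` gives 41000 nM
compound 3 `C[C@H]1CC[C@@H]2[C@@H](OC(=O)[C@]23CC(c2ccc([N+](=O)[O-])cc2)=NO3)[C@]2(C)C(=O)C=C[C@@]12O` gives 9000 nM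

These compounds share one core and differ only in the aromatic group on the carbon with a double bond to nitrogen. Compound 3, at 9000 nM, has the lowest number of the three, and so is the strongest inhibitor here. Compound 4 `C[C@H]1CC[C@@H]2[C@@H](OC(=O)[C@]23CC(c2ccccc2F)=NO3)[C@]2(C)C(=O)C=C[C@@]12O` has not yet been measured. It keeps the core and makes a single change: 2-fluorophenyl in place of 4-nitrophenyl on a carbon with a double bond to nitrogen, with 2-fluorophenyl in place of 4-nitrophenyl.

Among the compounds with values here, three measured steps bear on this change. Putting 4-methoxyphenyl in place of 2,6-dichlorophenyl gave a 1.0-fold lower number from compound 1 to compound 2 (0.02 log units; within the scatter), so those two groups cannot be told apart in this assay. Only the 4-nitrophenyl group stands apart, with a 4.8-fold lower number from compound 1 to compound 3 (0.68 log units; beyond the scatter) and a 4.6-fold lower number from compound 2 to compound 3 (0.66 log units; beyond the scatter), both modest. Within the data shown here, compound 4 gives up that group, so it is expected to move back towards compound 1 and compound 2, though no measured compound carries fluorine. The expected result is a 3.1-fold higher number from compound 3 to compound 4 (0.49 log units; beyond the scatter), a modest move to a higher number. For compound 4 the estimate is 28000 nM, with an expected range of 11000 nM to 60000 nM.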

Compound 4, half-maximal inhibitory concentration: 11000 nM
Estimate against measurement, compound 4: 2.5-fold (0.41 log units) above, within the range that was stated.
By their numbers in this assay, from the lowest: compounds 3 and 4 (each within the scatter of the next); then compounds 2 and 1 (each within the scatter of the next).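

In this assay, the 4-nitrophenyl group no longer stands alone, as the change to 2-fluorophenyl gave a 1.2-fold higher number from compound 3 to compound 4 (0.09 log units; within the scatter) and the two groups cannot be told apart. The lower numbers at this position therefore do not require a nitro group or its hydrogen-bond acceptors, since 2-fluorophenyl has none and still gave a 3.7-fold lower number from compound 2 to compound 4 (0.57 log units; beyond the scatter) and a 3.9-fold lower number from compound 1 to compound 4 (0.59 log units; beyond the scatter) with both steps modest. The four aromatic groups now form two pairs, compounds 3 and 4 on the lower side and compounds 1 and 2 on the higher side, but nothing here explains that split.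

With only four groups, no rule links the substituent on the aromatic ring to the number, and plain phenyl would show whether an unsubstituted ring sits with the lower pair or the higher one. Going by these compounds, it also remains open whether this position needs an aromatic ring at all, which a cyclohexyl group or a short chain ending in an amine would test.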